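The source may hold more compounds than are shown below. What is called first, only, known or untested is meant among the compounds shown, and "the series" means these compounds.

Compounds measured:
compound 1 `CC1CCC(Nc2nc(C(F)(F)F)ccc2CNC(=O)C(C)c2ccc(NS(C)(=O)=O)c(F)c2)CC1`, 27.2 nM
compound 2 `CC(C(=O)NCc1ccc(C(F)(F)F)nc1Nc1ccccc1)c1ccc(NS(C)(=O)=O)c(F)c1`, 59.6 nM
compound 3 `CC(C(=O)NCc1ccc(C(F)(F)F)nc1N(C)C)c1ccc(NS(C)(=O)=O)c(F)c1`, 19.1 nM

In a functional assay on CHO-K1 cells for antagonist activity at transient receptor potential cation channel subfamily V member 1 (Homo sapiens), read by FLIPR (on this read-out higher numbers stand for weaker inhibition and lower numbers for stronger inhibition), compound 1 stands second highest of the three numbers; compound 3 is nearest, a 1.4-fold lower number from compound 1 to compound 3 (0.15 log units; within the scatter), and compound 2 furthest, a 2.2-fold higher number from compound 1 to compound 2 (0.34 log units; beyond the scatter). Compound 4 `CC(C(=O)NCc1ccc(C(F)(F)F)nc1N1CCCC1)c1ccc(NS(C)(=O)=O)c(F)c1` differs from compound 1 by pyrrolidin-1-yl in place of (4-methylcyclohexyl)amino on an aromatic carbon. Going by the values given here, two measured steps bear on this: the replacement of the (4-methylcyclohexyl)amino group by dimethylamino, a 1.4-fold lower number from compound 1 to compound 3 (0.15 log units; within the scatter), and the replacement of anilino by dimethylamino, a 3.1-fold lower number from compound 2 to compound 3 (0.49 log units; beyond the scatter). Pyrrolidin-1-yl resembles dimethylamino more than it does (4-methylcyclohexyl)amino, so compound 4 is expected to land close to compound 3, with a step of a 1.5-fold lower number from compound 1 to compound 4 (0.18 log units; within the scatter) that may fall within the scatter. For compound 4 the estimate is 18 nM, ranging from 7 nM to 45 nM.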

Compound 4, inhibition constant: 0.6 nM
Beside the measured number, compound 4's estimate is 30-fold (1.48 log units) above it; measured number outside the range, below it.
By their numbers in this assay, from the lowest: compound 4; then compounds 3 and 1 (each within the scatter of the next); then compound 2.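

In this assay, pyrrolidin-1-yl on this aromatic carbon next to the ring nitrogen gives large steps from all three earlier groups (a 32-fold lower number from compound 3 to compound 4 (1.50 log units; beyond the scatter); a 45-fold lower number from compound 1 to compound 4 (1.66 log units; beyond the scatter); a 99-fold lower number from compound 2 to compound 4 (2.00 log units; beyond the scatter)). Compound 1 and compound 3 lie within the scatter of each other despite carrying very different groups, which suggested a tolerant position, but compound 4 shows that the read-out here depends sharply on the exact group. No evidence at hand explains this jump.

The compounds shown leave open whether the gain is particular to the five-membered ring. Piperidine, azetidine or morpholine on the same carbon would bear on that.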